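Removing the acetyl from compound 2

A few compounds are considered here, and "the series" means these few. Any claim that something is new, unique, unknown or untested is made for them only; others in the source may bear on it.

Measured in a functional assay for inhibition, with Rattus norvegicus as the target; a higher number here means a weaker inhibitor, a lower number a stronger inhibitor
Compound 1 `CCc1c(CC)c(OC)c2c(OC)cccc2c1OC(C)=O` gives 890 nM
Compound 2 `CCCCc1cc(OC)c2occc2c1OC(C)=O` gives 110 nM

Going by the values given here, only two compounds have been measured so far. Compound 2 (110 nM) holds the lower of the two numbers and so shows the stronger inhibition, while compound 1 (890 nM) lies above it by more than the scatter. The two differ in more than one place, so their gap cannot be tied to any single group. Among the compounds with values here, both carry the acetoxy group, which means that no measurement yet shows what its loss does.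

Compound 3 `CCCCc1cc(OC)c2occc2c1O` is compound 2 with one change, hydrogen in place of acetyl on an oxygen on an aromatic ring, that is, acetoxy to hydroxy. Within the data shown here, with no measured pair as a guide, the expectation in this assay is a small step, leaning slightly toward a higher number and staying within the scatter. The expected step is the one (a 1.4-fold higher number from compound 2 to compound 3 (0.13 log units; within the scatter)). Compound 3 is estimated at 150 nM (40 nM to 600 nM).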

Compound 3, half-maximal inhibitory concentration: 11900 nM
Estimate against measurement, compound 3: 79-fold (1.90 log units) below; measured number outside the range, above it.
By their numbers in this assay, from the lowest: compound 2; then compound 1; then compound 3.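

In this assay, putting hydrogen in place of acetyl on the oxygen on an aromatic ring gives a 110-fold higher number from compound 2 to compound 3 (2.03 log units; beyond the scatter) and shows that this position is highly sensitive to the change. Going by these compounds alone, the earlier compounds both carried the acetoxy group, so they could show nothing about its role; this pair now isolates it, as the only difference between compound 2 and compound 3 is acetoxy to hydroxy, and the step lies well beyond the scatter. Within this pair, therefore, the acetylated form is clearly the stronger inhibitor, and the free hydroxy form retains only a small part of that inhibition, although no information at hand explains the loss.

The compounds shown leave open whether the acetyl itself is needed, or whether another group on that oxygen, such as a propionyl, a benzoyl or a simple methyl, would keep the number near that of compound 2. They also leave open whether the same change on compound 1, with its different core and substituents, would produce a step of similar size.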